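Aryl-ethenyl in place of the carbamoyl-ethenyl of compound 3

This account rests on a few compounds, and the source may have more. Where it says the series, first, only, none or still open, it means among the compounds named here.

Compound 3 `COC(=O)/C=C/c1cccc(N(Cc2ccc(/C=C/C(=O)NC(C)(C)C)cc2)C(=O)C2CCCCC2)c1` gives > 1000 nM in an assay on isolated protein with Bile acid receptor (Homo sapiens) as the target (on this read-out lower numbers stand for an effect already at smaller amounts and higher numbers for an effect only at larger amounts of compound), which is a limit and not a number; it marks (the limit of > 1000 nM in this assay, at which 1 of the 3 values shown sits). Compound 1 `COC(=O)/C=C/c1cccc(N(Cc2ccc(/C=C/c3ccccn3)cc2)C(=O)C2CCCCC2)c1` gives 309 nM in this assay, and compound 2 `COC(=O)/C=C/c1cccc(N(Cc2ccc(-c3c(OC)cccc3OC)cc2)C(=O)C2CCCCC2)c1` gives 77 nM. Compound 4 `COC(=O)/C=C/c1cccc(N(Cc2ccc(/C=C/c3c(Cl)cccc3Cl)cc2)C(=O)C2CCCCC2)c1` differs from compound 3 in one place: 2,6-dichlorophenyl in place of (tert-butyl)carbamoyl on a double-bonded chain carbon bound to a double-bonded chain carbon. The measured steps that bear on this are an at least 3.2-fold higher number from compound 1 to compound 3 (0.51 log units; beyond the scatter) and an at least 12-fold higher number from compound 2 to compound 3 (1.11 log units; beyond the scatter), both running from an aromatic ring toward the carbamoyl. The step to compound 4 runs the other way, restoring an aromatic ring on the double-bonded chain carbon as in compound 1, so a step toward lower numbers of about the size of a 4.0-fold lower number from compound 1 to compound 2 (0.60 log units; beyond the scatter) is expected. Compound 4 is estimated at 150 nM, between 40 nM and 600 nM, an expected step of an at least 6.6-fold lower number from compound 3 to compound 4 (0.82 log units; beyond the scatter).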

Compound 4, half-maximal effective concentration: 150 nM
Estimate against measurement, compound 4: no gap at the digits printed, within the range that was stated.
By their numbers in this assay, from the lowest: compounds 2 and 4 (each within the scatter of the next); then compound 1. At a limit, above all of these: compound 3.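

In this assay, 2,6-dichlorophenyl on the double-bonded chain carbon gives an at least 6.6-fold lower number from compound 3 to compound 4 (0.82 log units; beyond the scatter), a bound only, since one end of this step is a limit: the limit of > 1000 nM in this assay, at which 1 of the 4 values shown sits.

On the same chain carbon the identity of the ring also counts, with 2,6-dichlorophenyl in place of pyridin-2-yl giving a 2.1-fold lower number from compound 1 to compound 4 (0.31 log units; beyond the scatter). The change from 2,6-dimethoxyphenyl to 2-(2,6-dichlorophenyl)ethenyl gives a 1.9-fold higher number from compound 2 to compound 4 (0.29 log units; within the scatter), so these two groups cannot be ordered.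

Open, as far as these compounds go, is whether the two chlorine atoms are needed, which an unsubstituted phenyl or a 2,6-dimethylphenyl on that chain carbon would test.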